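A few compounds are considered here, and "the series" means these few. Any claim that something is new, unique, unknown or untested is made for them only; others in the source may bear on it.

Three ester or carbamate analogues built on one shared core have been measured in a functional assay on U-251 cells (Homo sapiens) for antiproliferative activity, read by sulforhodamine B assay, with a stated time of 48 h, tested at 50 uM; a higher number here means more inhibition at the concentration tested (going by the name of the read-out), a lower number less inhibition. Compound 1 `CC1=CC[C@H](C(C)C)c2cc(C)c(OC(=O)Nc3ccccc3)cc21` carries an anilino group on the carbonyl carbon and gives 100%. Compound 2 `CC1=CC[C@H](C(C)C)c2cc(C)c(OC(=O)c3ccc(Cl)cc3)cc21` gives 25.6%, and compound 3 `CC1=CC[C@H](C(C)C)c2cc(C)c(OC(=O)c3cccc(Cl)c3)cc21` gives 0.9%, the lowest of the three numbers. The two steps from compound 1 were large: a number 74.4 percentage points lower from compound 1 to compound 2 (beyond the scatter) and a number 99.1 percentage points lower from compound 1 to compound 3 (beyond the scatter). The step between the two chlorophenyl compounds was smaller but still beyond the scatter: a number 24.7 percentage points lower from compound 2 to compound 3 (beyond the scatter).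

Compound 4 `CC1=CC[C@H](C(C)C)c2cc(C)c(OC(=O)c3cccc([N+](=O)[O-])c3)cc21` is not yet measured. It differs from compound 3 in one place: nitro in place of chloro on an aromatic carbon. For the measured compounds named here, none of the measured steps swaps chloro for nitro, so nothing among them speaks directly to this change; all three concern the aromatic ring or the position of a chloro substituent. Compound 3 already sits near the bottom of the scale, leaving little room to fall. Compound 4 is therefore expected to stay close to compound 3, with a step of a number 7.1 percentage points higher from compound 3 to compound 4 (within the scatter) that is not expected to exceed the scatter. The estimate for compound 4 in this assay is 8%, between 0% and 40%.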

Compound 4, a percentage reported as inhibition, at one concentration (the size of the read-out at that concentration, not a potency): 44%
Compound 4: middle estimate off by 36 percentage points, on the low side; measured number above the stated range.
By their numbers in this assay, from the lowest: compound 3; then compound 2; then compound 4; then compound 1.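

Swapping chloro for nitro on this aromatic carbon, meta to a large group, gives a number 43.1 percentage points higher from compound 3 to compound 4 (beyond the scatter) in this assay, so a single substituent at this position can move the read-out a long way. The nitro ester also gives a number 18.4 percentage points higher from compound 2 to compound 4 (beyond the scatter), placing it above both chlorophenyl esters, yet the anilino carbamate remains well ahead, with a number 56 percentage points lower from compound 1 to compound 4 (beyond the scatter). No measurement shown explains why nitro and chloro differ so much here.

On these data alone, it remains open whether the rise is specific to nitro or would also appear with another group at this position, such as an amine, a nitrile or a carboxylic acid. As far as these compounds go, it is also open how the anilino carbamate would respond to a chloro or nitro on its own aromatic ring.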